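A methyl step on a core held at the limit

The source may hold more compounds than are shown below. What is called first, only, known or untested is meant among the compounds shown, and "the series" means these compounds.

In a functional assay on MCF7 cells (Homo sapiens) for antiproliferative activity, read by MTT assay, with a stated time of 72 h (a higher number here means a weaker inhibitor, a lower number a stronger inhibitor), compound 1 `C[Si](C)(C)CCOCn1c(CC(O)COCc2ccccc2)cc(=O)[nH]c1=O` gives > 100000 nM, a limit of the assay.
In this assay compound 2 `Cc1c(CC(O)COCc2ccccc2)n(COCC[Si](C)(C)C)c(=O)[nH]c1=O` gives > 100000 nM, also a limit.
In this assay compound 3 `C[Si](C)(C)CCOCn1c(CC(O)CO)cc(=O)[nH]c1=O` gives > 100000 nM, again a limit.

Compound 3 thus stands only at a limit; (the limit of > 100000 nM in this assay, at which 3 of the 3 values shown sit). Compound 4 `Cc1c(CC(O)CO)n(COCC[Si](C)(C)C)c(=O)[nH]c1=O` differs from compound 3 by methyl in place of hydrogen on an aromatic carbon. The same change has been measured once before: a step that the two limits leave unreadable from compound 1 to compound 2. That step gives no readable size, so no step beyond the scatter can be foreseen in this assay, in either direction. Compound 4 is therefore expected to give about 200000 nM, with a range from 50000 nM to 1000000 nM. The step this estimate means, a step that the limit leaves unreadable from compound 3 to compound 4, is expected to stay within the scatter.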

Compound 4, half-maximal inhibitory concentration: > 100000 nM
Compound 4 was reported as a limit (the forecaster's own chance of this, stated with the estimate: 85%); the middle value is on the limit's open side.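

In this assay compound 4 gives > 100000 nM, a limit of the assay. Its steps from compound 3 and compound 2 therefore cannot be read. The compounds shown leave open whether either change, methyl or benzyl, affects activity at all: the limit of > 100000 nM in this assay, at which 4 of the 4 values shown sit.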